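The source may hold more compounds than are shown below. What is called first, only, known or untested is meant among the compounds shown, and "the series" means these compounds.

In an assay on cells for inhibition of Amine oxidase [flavin-containing] A (Homo sapiens), read by Amplex Red, with stated times of 30 min and 45 min (on this read-out lower numbers stand for stronger inhibition and higher numbers for weaker inhibition), compound 1 `C#CCCCOc1ccc2oc(=O)c(C(=O)OC)cc2c1` reports only a limit, > 10000 nM. Compound 2 `COC(=O)c1cc2cc(OCc3cccc(Cl)c3)ccc2oc1=O` likewise reports only a limit in this assay, > 10000 nM. The step that the two limits leave unreadable from compound 1 to compound 2 is therefore not readable, and compound 2 stands at the limit that both values shown share, (the limit of > 10000 nM in this assay, at which 2 of the 2 values shown sit). Compound 3 `COC(=O)c1cc2cc(OCCc3ccc(Cl)cc3)ccc2oc1=O` carries the change (4-chlorobenzyl in place of 3-chlorophenyl on a saturated chain carbon bound to an oxygen on an aromatic ring). Among the compounds with values here, no measured step bears on this change in readable size, so no step beyond the scatter is expected in this assay; the expected step that the limit leaves unreadable from compound 2 to compound 3 from compound 2 to compound 3 is taken as near nil. Compound 3 is estimated at 20000 nM, within 5000 nM to 100000 nM, with a limit again the likely outcome.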

Compound 3, half-maximal inhibitory concentration: > 10000 nM
Compound 3 ended at the assay's limit; the forecaster's own chance of this, stated with the estimate: 85%; the middle value lies beyond the limit too.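

The steps among compound 1, compound 2 and compound 3 cannot be read in this assay, since all three report only a limit: the limit of > 10000 nM in this assay, at which 3 of the 3 values shown sit.
The compounds shown leave open which group on this chain, if any, gives a readable inhibition value.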